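Cyano Substitution on the Isoxazole-Phenyl Arm of Compound 1

A few compounds are considered here, and "the series" means these few. Any claim that something is new, unique, unknown or untested is made for them only; others in the source may bear on it.

Measured compounds:
compound 1 `O=[N+]([O-])c1ccc(CN2CCC(n3cc(CC(OCc4cc(-c5ccccc5)no4)c4ccc(Br)cc4)nn3)CC2)cc1` — 7000 nM
compound 2 `O=[N+]([O-])c1ccc(CN2CCC(n3cc(CC(OCc4cc(-c5ccc(Br)cc5)no4)c4ccc(Br)cc4)nn3)CC2)cc1` — 2000 nM
compound 3 `O=[N+]([O-])c1ccc(CN2CCC(n3cc(CC(OCc4cc(-c5cccc(Br)c5)no4)c4ccc(Br)cc4)nn3)CC2)cc1` — 3000 nM

In a functional assay on Huh-7 cells (Homo sapiens) for cytotoxicity, with a stated time of 48 h (on this read-out higher numbers stand for weaker inhibition and lower numbers for stronger inhibition), compound 1 gives the highest number of the three, with compound 3 nearest and compound 2 furthest from it. Compound 4 `N#Cc1cccc(-c2cc(COC(Cc3cn(C4CCN(Cc5ccc([N+](=O)[O-])cc5)CC4)nn3)c3ccc(Br)cc3)on2)c1` differs from compound 1 by a single change: cyano in place of hydrogen on an aromatic carbon. The group enters on the six-membered aromatic ring of carbon only, meta to a large group, the same ring that carries the change in the two measured steps from compound 1. Those steps are the ones that bear on the new compound: a 3.5-fold lower number from compound 1 to compound 2 (0.54 log units; beyond the scatter), and a 2.3-fold lower number from compound 1 to compound 3 (0.37 log units; beyond the scatter). Both were modest lowerings, and the step between them, a 1.5-fold higher number from compound 2 to compound 3 (0.18 log units; within the scatter), shows that placing the substituent at either position gave about the same result. A cyano group is not a bromo group, so the author treats the size of the expected step with caution, but a modest lowering of the number is the most likely outcome for compound 4, which is estimated at a 2.0-fold lower number from compound 1 to compound 4 (0.30 log units; within the scatter). The author therefore expects compound 4 to give 3500 nM in this assay, within a range of 1500 nM to 8000 nM.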

Compound 4, half-maximal inhibitory concentration: 3000 nM
For compound 4 the middle estimate is 1.2-fold (0.07 log units) above the measured one; the range from low to high includes it.
By their numbers in this assay, from the lowest: compounds 2, 3 and 4 (each within the scatter of the next); then compound 1.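

In this assay, the lowering seen with bromo on this ring is not particular to bromo: cyano in place of hydrogen on the same ring gives a 2.3-fold lower number from compound 1 to compound 4 (0.37 log units; beyond the scatter). Cyano in place of bromo at the same place gives no change at the digits printed from compound 3 to compound 4 (within the scatter), and 3-cyanophenyl in place of 4-bromophenyl gives a 1.5-fold higher number from compound 2 to compound 4 (0.18 log units; within the scatter), so these steps do not separate the cyano compound from either bromo compound. Nothing available explains why either group lowers the number relative to the unsubstituted phenyl of compound 1.

The compounds shown leave open whether an amine, a carboxylic acid or a methoxy group on this ring would lower the number in the same way. They also leave open how 4-cyanophenyl would compare with 3-cyanophenyl.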